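The source may hold more compounds than are shown below. What is called first, only, known or untested is meant among the compounds shown, and "the series" means these compounds.

Compound 1 `CCOc1ccc(/C=C2\CN(CC(=O)O)c3c(C)cccc3C2=O)cc1` gives 42.4% in an assay on HL-60 cells for inhibition of glutathione S-transferase P (Homo sapiens), read by spectrophotometry, tested at 20 uM; a lower number here means less inhibition, a higher number more inhibition at the concentration tested (going by the name of the read-out). Within the data shown here, compound 2 `COc1ccc(/C=C2\CN(CC(=O)O)c3ccc(C)cc3C2=O)c(OC)c1OC` gives 5.68% in this assay, a number beyond the scatter below that of compound 1, so compound 1 stands highest of the two numbers measured so far. Compound 3 `COc1ccc(/C=C2\CN(CC(=O)O)c3c(C)cccc3C2=O)cc1` differs from compound 1 in one place: hydrogen in place of methyl on a saturated chain carbon bound to an oxygen on an aromatic ring. Among the measured compounds shown here, no measured pair shows this change on its own, so its size cannot be read from the data. The step is expected to be a number 7.4 percentage points lower from compound 1 to compound 3 (within the scatter), a small loss that may lie within the scatter. Compound 3 is expected to give 35%, with a range from 15% to 55%.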

Compound 3, a percentage reported as inhibition, at one concentration (the size of the read-out at that concentration, not a potency): 31.5%
The estimate for compound 3 lay 3.5 percentage points above the measured number, within the range that was stated.
By their numbers in this assay, from the lowest: compound 2; then compound 3; then compound 1.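

In this assay, among these compounds, ethoxy to methoxy gives a number 10.9 percentage points lower from compound 1 to compound 3 (beyond the scatter) and is the first change seen on its own. The number at this position therefore responds to the removal of a single methyl, although compound 3 still gives 31.5% and so retains part of the inhibition. No measurement available bears on the reason for this step. Open, going by these compounds, is whether a longer chain such as propoxy raises the number beyond that of compound 1. Also open, on these data alone, is how an amine or a carboxylic acid at the end of this chain would read.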